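Swapping the Aryl Group on a Shared Core

The source may hold more compounds than are shown below. What is called first, only, known or untested is meant among the compounds shown, and "the series" means these compounds.

Compounds measured so far:
Compound 1, `Cc1cc(-c2ccc(O)cc2)c2ncc(CSCCc3ccccc3)n2c1`: in an ADME assay on HEL cells (Homo sapiens) for cytotoxicity, with a stated time of 3 days (a higher number here means that more compound is tolerated, a lower number that less compound is tolerated), compound 1 gives 13.7 ug/mL.
Compound 2, `COc1cccc(-c2cc(C)c3ncc(CSCCc4ccccc4)n3c2)c1`: in this assay compound 2 gives 36 ug/mL.
Compound 3, `Cc1cc(-c2ccc(C#N)cc2)cn2c(CSCCc3ccccc3)cnc12`: in this assay compound 3 gives 10.6 ug/mL.

Compound 1 stands second highest of the three numbers. Its nearest neighbour is compound 3, whose number lies within the scatter of that of compound 1, while compound 2 lies further off, beyond the scatter. Among the compounds with values here, only one step between measured compounds changes a single place: a 3.4-fold lower number from compound 2 to compound 3 (0.53 log units; beyond the scatter).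

Compound 4, `Cc1cc(-c2cccc([N+](=O)[O-])c2)c2ncc(CSCCc3ccccc3)n2c1`, is the compound still to be measured. It differs from compound 1 in 3-nitrophenyl in place of 4-hydroxyphenyl on an aromatic carbon. Within the data shown here, no measured step replaces 4-hydroxyphenyl with 3-nitrophenyl, so the step from compound 2 to compound 3 serves only as a gauge of how far an aryl swap on this core has moved the number so far, and that movement was modest. Without a direct precedent the direction cannot be read from the data; a step no larger than that one, in either direction, is what is expected in this assay. The step from compound 1 to compound 4 is expected to be a 1.1-fold lower number from compound 1 to compound 4 (0.06 log units; within the scatter). Compound 4 is therefore estimated at 12 ug/mL, with a range from 4.5 ug/mL to 32 ug/mL.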

Compound 4, half-maximal cytotoxic concentration: 47 ug/mL
Estimate against measurement, compound 4: 3.9-fold (0.59 log units) below; the measured number lies above the stated range.
By their numbers in this assay, from the lowest: compounds 3 and 1 (each within the scatter of the next); then compounds 2 and 4 (each within the scatter of the next).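

With a 3.4-fold higher number from compound 1 to compound 4 (0.54 log units; beyond the scatter) in this assay, the aryl group on the carbon ortho to a fused ring and meta to a methyl group is shown for the first time to move the number beyond the scatter. The aryl groups of compound 2 and compound 3 stand on another carbon of the core, so the earlier step (a 3.4-fold lower number from compound 2 to compound 3 (0.53 log units; beyond the scatter)) spoke about a different place and a different pair of groups, and it gave no direct reading of this position. The change removes 4-hydroxyphenyl with its hydrogen-bond donor and brings in 3-nitrophenyl, yet no measurement at hand explains the rise and the account of it ends with the numbers themselves.

The compounds shown do not separate the loss of the 4-hydroxyphenyl group from the arrival of the 3-nitrophenyl group, since neither 3-hydroxyphenyl nor 4-nitrophenyl appears on this carbon. Also open, on these data alone, is how an aminophenyl or a carboxyphenyl group on this carbon would stand, and whether the same swap would move the number alike on the other carbon.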